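From 4-bromophenyl to 3-chlorophenyl in compound 4

This account rests on a few compounds, and the source may have more. Where it says the series, first, only, none or still open, it means among the compounds named here.

Compound 1 `COc1ccc(/C=C/C(=O)/C=C/c2cc3ccccc3nc2Oc2ccc(Br)cc2)c(OC)c1`: > 10000 nM, a limit
Compound 2 `COc1ccc(OC)c(/C=C/C(=O)/C=C/c2cc3ccccc3nc2Oc2ccc(Br)cc2)c1`: > 10000 nM, a limit
Compound 3 `COc1ccc(/C=C/C(=O)/C=C/c2cc3ccccc3nc2Oc2ccc(Br)cc2)cc1OC`: > 10000 nM, a limit

In a functional assay on HeLa cells (Homo sapiens) for cytotoxicity, read by MTT assay, with a stated time of 48 h (a lower number here means a stronger inhibitor, a higher number a weaker inhibitor), compound 2 stands at the limit of > 10000 nM in this assay, at which 3 of the 3 values shown sit, so it has a limit and no number. Compound 4 `COc1ccc(OC)c(/C=C/C(=O)/C=C/c2cc3ccccc3nc2Oc2cccc(Cl)c2)c1` differs from it on an oxygen on an aromatic ring: 3-chlorophenyl in place of 4-bromophenyl on an oxygen on an aromatic ring. The measured steps touching compound 2, a step that the two limits leave unreadable from compound 1 to compound 2 and a step that the two limits leave unreadable from compound 2 to compound 3, concern the dimethoxyphenyl group instead, and neither has a readable size. No step beyond the scatter is therefore expected in this assay, and another limit is the likeliest report. The estimated change is a step that the limit leaves unreadable from compound 2 to compound 4. For compound 4 the expected value is 15000 nM, with an estimated range of 5000 nM to 50000 nM.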

Compound 4, half-maximal inhibitory concentration: > 10000 nM
Compound 4: only a limit was reported; the forecaster's own chance of this, stated with the estimate: 75%; the middle value does not contradict the limit.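

No size can be read for the change from compound 2 to compound 4, as both are reported only as limits. The compounds shown leave open whether 3-chlorophenyl in place of 4-bromophenyl alters cytotoxicity at all.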